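The source may report more compounds than this note shows. Statements on the series, on what has been measured and on what is new or still open speak of the compounds shown alone.

Compound 3 `Cc1cccc(NS(=O)(=O)c2cccc(CCCCCCNC(=O)/C=C/c3cccnc3)c2)c1` is one of three analogues tested in an assay on isolated protein for inhibition of Nicotinamide phosphoribosyltransferase (Homo sapiens), read by WST assay, with stated times of 60 min, 5 min and 30 min, in the presence of a further agent that is not named here; on this read-out lower numbers stand for stronger inhibition and higher numbers for weaker inhibition. In this assay compound 3 gives 12.3 nM, the second highest of the three numbers. Within the data shown here, compound 2 `O=C(/C=C/c1cccnc1)NCCCCCCc1cccc(S(=O)(=O)Nc2ccccc2)c1` gives 10.5 nM in this assay, and the step of a 1.2-fold higher number from compound 2 to compound 3 (0.07 log units; within the scatter) is the only directly comparable change in the set. Compound 1 `O=C(/C=C/c1cccnc1)NCCCCCCCc1ccc(S(=O)(=O)Nc2ccccc2)cc1`, which carries a longer chain and a different attachment pattern, gives 16.4 nM in this assay; the two values of compound 1 and compound 3 lie within the scatter of each other, so nothing separates them.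

Compound 4 `CC(C)(C)c1ccc(NS(=O)(=O)c2cccc(CCCCCCNC(=O)/C=C/c3cccnc3)c2)cc1` is not yet measured. It differs from compound 3 by 4-(tert-butyl)phenyl in place of 3-methylphenyl on a sulfonamide nitrogen. Among the measured compounds shown here, the one change in the set that touches the same part of the molecule, an added methyl on the aromatic ring of the aniline, moved the number in this assay only within the scatter. For the measured compounds named here, no measured step covers a tert-butyl group or a change of substitution pattern on that ring, so the expectation rests on that single small step alone. On this basis the step of a 1.2-fold higher number from compound 3 to compound 4 (0.09 log units; within the scatter) is expected to be small, most likely within the scatter, with a mild lean toward a higher number. Compound 4 is therefore estimated at 15 nM in this assay, within a range from 6 nM to 40 nM.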

Compound 4, half-maximal inhibitory concentration: 9.47 nM
Beside the measured number, compound 4's estimate is 1.6-fold (0.20 log units) above it; the measured number falls inside the stated range.
By their numbers in this assay, from the lowest: compounds 4, 2, 3 and 1 (each within the scatter of the next).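

Replacing 3-methylphenyl with 4-(tert-butyl)phenyl on a sulfonamide nitrogen raises the group from 7 to 10 carbon heavy atoms and gives a 1.3-fold lower number from compound 3 to compound 4 (0.11 log units; within the scatter) in this assay, so this larger group leaves the number within the scatter. Measured against the hydrogen-bearing ring, the added tert-butyl gives a 1.1-fold lower number from compound 2 to compound 4 (0.04 log units; within the scatter) and the methyl change gives a 1.2-fold higher number from compound 2 to compound 3 (0.07 log units; within the scatter), so among compounds 2, 3 and 4 neither added group separates from the unsubstituted ring, and none of the three goes against this. No measurement given here bears on why these groups leave the number within the scatter.

The step to compound 4 alters the group and its place on the ring together, so the compounds shown do not separate the effect of tert-butyl from that of its position. They also leave open whether a ring carrying something other than carbon substituents, such as a carboxylic acid or an amine, would move the number beyond the scatter, since all the groups shown here contain carbon only.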